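Cytotoxicity on the shared core: furan, ethoxyphenyl, benzodioxin

A few compounds are considered here, and "the series" means these few. Any claim that something is new, unique, unknown or untested is made for them only; others in the source may bear on it.

Measured so far in an ADME assay on HEK293 cells (Homo sapiens) for cytotoxicity, read by CellTiter-Glo and resazurin assay, with a stated time of 72 h; a lower number here means that less compound is needed, a higher number that more compound is needed for the effect:
- compound 1 `CC(C)N(Cc1cccc(OCCCCCC(=O)O)c1)C(=O)c1ccc(-c2ccco2)cc1` gives > 26000 nM, a limit of the assay.
- compound 2 `CCOc1cccc(-c2ccc(C(=O)N(Cc3cccc(OCCCCCC(=O)O)c3)C(C)C)cc2)c1` gives > 20800 nM, a limit of the assay.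

Compound 2 stands at a limit in this assay; the other value shown is a limit too (the limit of > 20800 nM in this assay, at which 1 of the 2 values shown sits, (the limit of > 26000 nM in this assay, at which 1 of the 2 values shown sits)). The step that the two limits leave unreadable from compound 1 to compound 2 is therefore not readable. Compound 3 `CC(C)N(Cc1cccc(OCCCCCC(=O)O)c1)C(=O)c1ccc(-c2ccc3c(c2)OCCO3)cc1` differs from compound 2 by 2,3-dihydro-1,4-benzodioxin-6-yl in place of 3-ethoxyphenyl on an aromatic carbon. Among the measured compounds shown here, no measured step bears readably on this change, so for compound 3 the expected step that the limit leaves unreadable from compound 2 to compound 3 is none beyond the scatter, most likely again a limit. The estimate for compound 3 is 30000 nM, range 15000 nM to 100000 nM.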

Compound 3, half-maximal effective concentration: > 21900 nM
Compound 3: a limit, no number (the forecaster's own chance of this, stated with the estimate: 80%); the middle value lies beyond the limit too.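

In this assay, among the compounds shown here, compound 1, compound 2 and compound 3 all stand at limits, and no step among them can be read. The compounds shown leave open whether furan-2-yl, 3-ethoxyphenyl and 2,3-dihydro-1,4-benzodioxin-6-yl differ at all in this read-out.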